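This account rests on a few compounds, and the source may have more. Where it says the series, first, only, none or still open, it means among the compounds named here.

Values so far in a functional assay on SK-MEL-28 cells (Homo sapiens) for antiproliferative activity, read by sulforhodamine B assay, with a stated time of 48 h (on this read-out lower numbers stand for stronger inhibition of growth and higher numbers for weaker inhibition of growth), are these.
Compound 1 `O=C(NCCCNc1cc(-c2cn(-c3ccccc3)nc2-c2cccc(O)c2)ccn1)Nc1ccc(F)cc1` gives 5640 nM
Compound 2 `O=C(NCCCNc1cc(-c2cn(-c3ccccc3)nc2-c2cccc(O)c2)ccn1)Nc1cccc(C(F)(F)F)c1` gives 7510 nM

Compound 1 has one measured neighbour and is not separated from it. The step reads a 1.3-fold higher number from compound 1 to compound 2 (0.12 log units; within the scatter) and is the only one available. Compound 3 `COc1cccc(-c2nn(-c3ccccc3)cc2-c2ccnc(NCCCNC(=O)Nc3ccc(F)cc3)c2)c1` differs from compound 1 at one place. The change is methyl in place of hydrogen on an oxygen on an aromatic ring and reads 3-hydroxyphenyl to 3-methoxyphenyl. Going by the values given here, the measured step lies on an amide-type nitrogen, so it says nothing direct about this oxygen, and no measured pair tests the change. It shows only that one replacement elsewhere on the core left the number within the scatter. No direction can be argued from the data, so the expectation is no shift beyond the scatter, held loosely. The expected step is a 1.2-fold higher number from compound 1 to compound 3 (0.09 log units; within the scatter) in this assay and the range stays wide. Compound 3 is estimated at 7000 nM with an expected range from 3000 nM to 16000 nM on this read-out.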

Compound 3, concentration for total growth inhibition: 15500 nM
Beside the measured number, compound 3's estimate is 2.2-fold (0.35 log units) below it, within the range that was stated.
By their numbers in this assay, from the lowest: compounds 1 and 2 (each within the scatter of the next); then compound 3.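

In this assay, going by these compounds alone, methyl in place of hydrogen on the oxygen of the 3-hydroxyphenyl group gives a 2.7-fold higher number from compound 1 to compound 3 (0.44 log units; beyond the scatter) and is the first step to lie beyond the scatter. The only earlier step, on the amide-type nitrogen, stayed within it, so this oxygen is the first place shown where a single change moves the number, here towards weaker inhibition of growth. Nothing available accounts for this shift.

Still open, going by these compounds, is whether a longer ether such as ethoxy would move the number further, and how an amine or a carboxylic acid in place of the hydroxy would read. Methoxy is also shown only with 4-fluorophenyl on the amide-type nitrogen, so its step with 3-(trifluoromethyl)phenyl there remains unknown.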